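The source may report more compounds than this note shows. Statements on the series, on what has been measured and on what is new or still open speak of the compounds shown alone.

Measured so far:
Compound 1, `Cc1ccc(C[C@H]2C(=O)OC[C@@H]2Cc2ccccc2)cc1`, gives 44000 nM in a functional assay on HL-60 cells (Homo sapiens) for cytotoxicity, read by WST assay, with a stated time of 48 h; on this read-out higher numbers stand for an effect only at larger amounts of compound and lower numbers for an effect already at smaller amounts.
Compound 2, `O=C1OC[C@H](Cc2ccccc2)[C@H]1Cc1ccc(F)cc1`, gives 57000 nM in this assay.
Compound 3, `Cc1ccccc1C[C@H]1COC(=O)[C@@H]1Cc1ccc(Cl)c(Cl)c1`, gives 22000 nM in this assay.

Compound 1 and compound 2 share one core and differ only by fluoro in place of methyl on an aromatic carbon; that change made a step of a 1.3-fold higher number from compound 1 to compound 2 (0.11 log units; within the scatter), so the two behave alike. Compound 3 sits on a different core; the difference between the two cores is not broken down here. Among the measured compounds shown here, compound 3 and compound 2 are the only pair whose values lie apart beyond the scatter, with compound 3 giving the lower number.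

Compound 4, `O=C1OC[C@H](Cc2ccccc2F)[C@H]1Cc1ccc(Cl)c(Cl)c1`, is not yet measured. It differs from compound 3 by fluoro in place of methyl on an aromatic carbon. This is the same kind of change as that from compound 1 to compound 2, though the place is not identical: there the group sat para to a large group, here it sits ortho to a large group. Because a 1.3-fold higher number from compound 1 to compound 2 (0.11 log units; within the scatter) lay within the scatter, a step of similar size is expected here, a 1.3-fold higher number from compound 3 to compound 4 (0.10 log units; within the scatter). For compound 4 in this assay the estimate is 28000 nM, with a likely range from 12000 nM to 65000 nM.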

Compound 4, half-maximal effective concentration: 28000 nM
Beside the measured number, compound 4's estimate shows no gap at the digits printed, within the range that was stated.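

In this assay, putting fluoro in place of methyl on the aromatic ring made a step of a 1.3-fold higher number from compound 3 to compound 4 (0.10 log units; within the scatter), so on this second core too the swap leaves the number within the usual scatter. Set side by side, the two steps agree: the same change on two cores in this assay, a 1.3-fold higher number (0.11 log units; within the scatter) from compound 1 to compound 2 and a 1.3-fold higher number (0.10 log units; within the scatter) from compound 3 to compound 4, 1.0-fold (0.01 log units) apart, within the scatter of two such steps. This shows that, in these two pairs, the swap has no effect that can be told from scatter, even though the group sits in a different place on each core, but it does not show that methyl and fluoro can be exchanged freely on other cores or in other tests, and it gives no reason for the match.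

The aromatic rings shown carry only methyl, fluoro and chloro, so it remains open whether an amine, a carboxylic acid or a longer chain such as propyl at the same place would move the number beyond the scatter. Also open, on these data alone, is whether the methyl-to-fluoro swap would stay this small on any core beyond these two.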